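Notes on the step from compound 1 to compound 4

The source may report more compounds than this note shows. Statements on the series, on what has been measured and on what is new or still open speak of the compounds shown alone.

Compound 1 `CCn1c(=O)/c(=C2\Sc3ccccc3N2C)s/c1=C\c1ccncc1Nc1ccccc1Cl` gives 780 nM in a functional assay on PC-3 cells (Homo sapiens) for inhibition; on this read-out lower numbers stand for stronger inhibition and higher numbers for weaker inhibition. Among the three measured compounds it stands second highest: compound 2 `CCn1c(=O)/c(=C2\Sc3cc(F)ccc3N2C)s/c1=C\c1ccncc1Nc1ccccc1Cl` gives 1200 nM, a step of a 1.5-fold higher number from compound 1 to compound 2 (0.19 log units; within the scatter), and compound 3 `CCn1c(=O)/c(=C2\Sc3ccc(C)cc3N2C)s/c1=C\c1ccncc1Nc1ccccc1Cl` gives 500 nM, a step of a 1.6-fold lower number from compound 1 to compound 3 (0.19 log units; within the scatter). Both steps are within the scatter, so the three values are not separated from one another.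

Compound 4 `CCn1c(=O)/c(=C2\Sc3ccccc3N2C)s/c1=C\c1ccncc1Nc1cc(F)ccc1F` has not been measured. It differs from compound 1 in one place: 2,5-difluorophenyl in place of 2-chlorophenyl on a nitrogen on an aromatic ring. Neither measured step touches this part of the molecule; the changes from compound 1 to compound 2 and from compound 1 to compound 3 sit elsewhere in the shared core, and both were within the scatter. Going by the values given here, no measured step therefore bears directly on the change from compound 1 to compound 4, and there is no ground to expect a step beyond the scatter in either direction in this assay. Compound 4 is expected to give about 900 nM, between 300 nM and 2700 nM, which corresponds to an expected step of a 1.2-fold higher number from compound 1 to compound 4 (0.06 log units; within the scatter).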

Compound 4, half-maximal inhibitory concentration: 1200 nM
Beside the measured number, compound 4's estimate is 1.3-fold (0.12 log units) below it, within the range that was stated.
By their numbers in this assay, from the lowest: compounds 3, 1, 2 and 4 (each within the scatter of the next, the first and the last beyond it).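

Going by these compounds alone, the replacement of 2-chlorophenyl by 2,5-difluorophenyl on a nitrogen on an aromatic ring is the first measured step at this position, and in this assay it reads (a 1.5-fold higher number from compound 1 to compound 4 (0.19 log units; within the scatter)). This position therefore accepts one halogenated phenyl in place of another without a step beyond the scatter, and the same holds for the fluoro and methyl replacements on the shared core. The swap takes out chlorine and brings in two fluorines in a single step, so the contribution of each cannot be separated, and no measurement on hand accounts for the result.

Plain phenyl and 2-fluorophenyl on this nitrogen would separate those contributions. Going by these compounds, whether this position stays within the scatter with a non-halogen group, such as a phenyl bearing a carboxylic acid or an amine, remains open.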